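Replacing a thiophene ring with a short alkyl chain

The compounds below may be only part of what the source reports. "The series", "measured", "known", "first", "only" and "open" are said of these compounds alone.

Compound 1 `CCc1nc(Cl)ncc1C(=O)Nc1cc(C(F)(F)F)cc(C(F)(F)F)c1` gives 400 nM in an assay on Jurkat cells for activation of nuclear factor NF-kappa-B complex (Homo sapiens); on this read-out lower numbers stand for stronger inhibition and higher numbers for weaker inhibition.
Compound 2 `O=C(Nc1cc(C(F)(F)F)cc(C(F)(F)F)c1)c1cnc(Cl)nc1-c1cccs1` gives 9800 nM in this assay.

Compound 2 stands highest of the two numbers measured; its nearest neighbour is compound 1, reached by the step of a 25-fold higher number from compound 1 to compound 2 (1.39 log units; beyond the scatter). Compound 3 `CCCc1nc(Cl)ncc1C(=O)Nc1cc(C(F)(F)F)cc(C(F)(F)F)c1` differs from compound 2 by propyl in place of thiophen-2-yl on an aromatic carbon. For the measured compounds named here, the one step that bears on this change is the large one from compound 1 to compound 2, which ran in the opposite direction. Compound 3 is therefore expected to move back towards the number of compound 1, by about a 20-fold lower number from compound 2 to compound 3 (1.29 log units; beyond the scatter) in this assay. Compound 3 is estimated at 500 nM, within a range of 150 nM to 1600 nM.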

Compound 3, half-maximal inhibitory concentration: 500 nM
Beside the measured number, compound 3's estimate shows no gap at the digits printed, within the range that was stated.
By their numbers in this assay, from the lowest: compounds 1 and 3 (each within the scatter of the next); then compound 2.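

In this assay, propyl in place of thiophen-2-yl on this aromatic carbon gives a 20-fold lower number from compound 2 to compound 3 (1.29 log units; beyond the scatter), so a second alkyl chain, not ethyl alone, reverses the large step seen with the thiophene. Adding one methyl to the saturated chain gives a 1.3-fold higher number from compound 1 to compound 3 (0.10 log units; within the scatter), so ethyl and propyl cannot be told apart here. Nothing available explains the gap between the alkyl chains and thiophen-2-yl.

Still open, on these data alone, is whether a longer chain such as butyl, a branched isopropyl group or a phenyl ring would stay with the alkyl compounds or move towards compound 2.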